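Series notes: replacing the arylamino group at the pyridine carbon

The compounds below may be only part of what the source reports. "The series", "measured", "known", "first", "only" and "open" are said of these compounds alone.

Of the compounds shown here, three have been measured in a functional assay on CHO-K1 cells for antagonist activity at transient receptor potential cation channel subfamily V member 1 (Homo sapiens), read by FLIPR; on this read-out lower numbers stand for stronger inhibition and higher numbers for weaker inhibition. Compound 1 `CC(C(=O)NCc1ccc(C(F)(F)F)nc1Nc1ccc(F)cc1)c1ccc(NS(C)(=O)=O)c(F)c1` gives 39.2 nM, and compound 2 `Cc1ccc(Nc2nc(C(F)(F)F)ccc2CNC(=O)C(C)c2ccc(NS(C)(=O)=O)c(F)c2)cc1C` gives 39.3 nM; the step of a 1.0-fold higher number from compound 1 to compound 2 (0.00 log units; within the scatter) shows that exchanging one arylamino group for another leaves the number unchanged. Compound 3 `CC(=O)OC1CCN(c2nc(C(F)(F)F)ccc2CNC(=O)C(C)c2ccc(NS(C)(=O)=O)c(F)c2)CC1` gives 4 nM, the lowest of the three numbers, with the steps of a 9.8-fold lower number from compound 1 to compound 3 (0.99 log units; beyond the scatter) and a 9.8-fold lower number from compound 2 to compound 3 (0.99 log units; beyond the scatter) both beyond the scatter.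

Compound 4 `CC(C(=O)NCc1ccc(C(F)(F)F)nc1N1CCN(C2CCCCC2)CC1)c1ccc(NS(C)(=O)=O)c(F)c1` carries the change (4-cyclohexylpiperazin-1-yl in place of 4-acetoxypiperidin-1-yl on an aromatic carbon). For the measured compounds named here, no measured step covers an exchange between two saturated amine groups at this carbon; the two informative steps, from compound 1 to compound 3 and from compound 2 to compound 3, only show that a saturated ring amine at this position gave a modest gain over either arylamino group. On that basis the step of a 2.0-fold higher number from compound 3 to compound 4 (0.30 log units; within the scatter) is expected to stay within the scatter or to be a small loss. Compound 4 is therefore estimated to give about 8 nM in this assay, within a range from 2 nM to 30 nM.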

Compound 4, inhibition constant: 21.6 nM
For compound 4 the middle estimate is 2.7-fold (0.43 log units) below the measured one; the range from low to high includes it.
By their numbers in this assay, from the lowest: compound 3; then compounds 4, 1 and 2 (each within the scatter of the next).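

The saturated ring amine at this carbon does not by itself bring the gain seen with compound 3: in this assay, 4-cyclohexylpiperazin-1-yl in place of 4-acetoxypiperidin-1-yl gives a 5.4-fold higher number from compound 3 to compound 4 (0.73 log units; beyond the scatter) and this step lies beyond the scatter. The 4-cyclohexylpiperazin-1-yl group is not separated from either arylamino group, with a 1.8-fold lower number from compound 2 to compound 4 (0.26 log units; within the scatter) and a 1.8-fold lower number from compound 1 to compound 4 (0.26 log units; within the scatter) both within the scatter, so among these four compounds only compound 3 stands apart. Nothing at hand explains the difference between the two saturated groups.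

Both the ring and its substituent change in this step, so it remains open which of them accounts for the difference. A 4-cyclohexylpiperidin-1-yl or 4-hydroxypiperidin-1-yl group at the same carbon would bear on that question.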